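This account rests on a few compounds, and the source may have more. Where it says the series, first, only, none or still open, it means among the compounds named here.

Measured in a functional assay on DU-145 cells (Homo sapiens) for cytotoxicity, read by MTT assay, with a stated time of 48 h; a lower number here means a stronger inhibitor, a higher number a weaker inhibitor:
- compound 1 `COc1cc(/C=C/c2ccc(C)cc2)c(-c2ccccc2)c(OC)c1OC`: 101000 nM
- compound 2 `C=C(c1ccc(OC)cc1)c1cc(OC)c(OC)c(OC)c1-c1ccccc1`: 8000 nM
- compound 3 `C=C(c1ccccc1)c1cc(OC)c(OC)c(OC)c1-c1ccccc1`: 36000 nM

Compound 3 takes the middle place of the three numbers in this assay, with compound 1 higher and compound 2 lower.

Compound 4 `C=C(c1ccc(C)cc1)c1cc(OC)c(OC)c(OC)c1-c1ccccc1` differs from compound 3 by one change, methyl in place of hydrogen on an aromatic carbon, para to a large group. The closest measured change sits on that same carbon: a 4.5-fold higher number from compound 2 to compound 3 (0.65 log units; beyond the scatter), with hydrogen in place of methoxy. Read backwards, this single pair suggests that a group there can lower the number, although methoxy is not methyl. The other step, a 2.8-fold lower number from compound 1 to compound 3 (0.45 log units; beyond the scatter), removes the methyl together with a change in the ethenyl link, so it does not isolate the methyl. Compound 1 also carries this methyl and still has the highest number, which argues against a firm trend.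

A modest move to a lower number is expected, smaller than the methoxy step. The expected step is a 2.3-fold lower number from compound 3 to compound 4 (0.35 log units; beyond the scatter). Compound 4 is estimated at 16000 nM, with an expected range of 6000 nM to 45000 nM.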

Compound 4, half-maximal inhibitory concentration: 28000 nM
The estimate for compound 4 lay 1.8-fold (0.24 log units) below the measured number, within the range that was stated.
By their numbers in this assay, from the lowest: compound 2; then compounds 4 and 3 (each within the scatter of the next); then compound 1.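

In this assay, methyl in place of hydrogen on this aromatic carbon, para to a large group, does not separate the two compounds (see a 1.3-fold lower number from compound 3 to compound 4 (0.11 log units; within the scatter)). Methoxy remains the only group of the three on this carbon that stands clear of the others, and methyl in place of methoxy gives the step (a 3.5-fold higher number from compound 2 to compound 4 (0.54 log units; beyond the scatter)), so a substituent as such does not account for the lower number of compound 2. With the methyl now held constant, 1-(4-methylphenyl)ethenyl in place of 2-(4-methylphenyl)ethenyl isolates the change in the link (see a 3.6-fold lower number from compound 1 to compound 4 (0.56 log units; beyond the scatter)).

As far as these compounds go, whether an amine, a carboxylic acid or a longer chain on this carbon would match methoxy remains open. No evidence on the reason for these differences accompanies the series.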